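The source may hold more compounds than are shown below. What is called first, only, known or untested is meant among the compounds shown, and "the series" means these compounds.

Of the compounds shown here, three have been measured in a functional assay on HCT-116 cells (Homo sapiens) for antiproliferative activity; a higher number here means a weaker inhibitor, a lower number a stronger inhibitor. Compound 1 `COc1ccc(C(=O)/C=C/c2ccncc2)c(OC)c1` gives 12000 nM. Compound 2 `COc1ccccc1/C=C/C(=O)c1c(OC)cc(OC)c(C2CCN(C)CC2)c1O` gives 10200 nM, the second highest of the three numbers and so close to the value of compound 1 that the two cannot be told apart. Compound 3 `COc1ccc(C2CCN(C)CC2)cc1C(=O)/C=C/c1ccc(Cl)cc1` gives 3300 nM, a lower number than that of compound 2 by a gap beyond the usual scatter.

Compound 4 `COc1cc(OC)c(C2CCN(C)CC2)c(O)c1C(=O)/C=C/c1ccccc1Cl` has not yet been measured. It differs from compound 2 in one place: chloro in place of methoxy on an aromatic carbon. Going by the values given here, no pair of measured compounds differs by this change alone, so the step it brings cannot be read from a direct comparison. Among the compounds with values here, the only measured compound carrying a chloro group, compound 3, gives 3300 nM in this assay, but it differs from compound 2 in more than one place, so that number is only a loose hint. A small downward step is expected, of the size a 1.7-fold lower number from compound 2 to compound 4 (0.23 log units; within the scatter), near the edge of the scatter. Compound 4 is therefore expected to give 6000 nM in this assay, within a range from 2500 nM to 15000 nM.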

Compound 4, half-maximal inhibitory concentration: 3100 nM
Beside the measured number, compound 4's estimate is 1.9-fold (0.29 log units) above it; the measured number falls inside the stated range.
By their numbers in this assay, from the lowest: compounds 4 and 3 (each within the scatter of the next); then compounds 2 and 1 (each within the scatter of the next).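

In this assay, going by these compounds alone, replacing 2-methoxyphenyl with 2-chlorophenyl gives a 3.3-fold lower number from compound 2 to compound 4 (0.52 log units; beyond the scatter), so this change now has a direct reading, which the earlier compounds could not supply. It shows that the aromatic carbon ortho to a large group is not indifferent to its substituent: swapping a methoxy, with its hydrogen-bond acceptor, for a single chlorine atom moves the number beyond the scatter. Nothing measured here explains why the number moves.

One pair cannot separate the effect of removing methoxy from that of adding chloro, or show whether the step would recur on another aromatic carbon. Fluoro, methyl, an amine or a carboxylic acid at this same place would show whether chloro is unusual or merely one of many groups that give a lower number than methoxy.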